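Methyl on the cyclopropyl sulfonamide: stability notes

A few compounds are considered here, and "the series" means these few. Any claim that something is new, unique, unknown or untested is made for them only; others in the source may bear on it.

Among the measured compounds shown here, compound 2 `CC[C@@H]1C[C@H](C)CC/C=C\[C@@H]2C[C@@]2(C(=O)NS(=O)(=O)C2CC2)NC(=O)[C@@H]2C[C@@H](Oc3ncc(OC)c4ccccc34)CN2C(=O)[C@H]1NC(=O)OC(C)(C)C(F)(F)F` carries the only single number in an ADME assay on microsomes from liver (Homo sapiens) for metabolic stability, read by LC-MS, using NADPH, with a stated time of 45 min; on this read-out higher numbers stand for a longer-lived compound and lower numbers for a shorter-lived compound: compound 2 gives 0.628 h, and a further entry for it yielded no single number. Compound 1 `COc1cnc(O[C@@H]2C[C@H]3C(=O)N[C@]4(C(=O)NS(=O)(=O)C5(C)CC5)C[C@H]4/C=C\CC[C@@H](C)C[C@@H](C)[C@H](NC(=O)OC(C)(C)C(F)(F)F)C(=O)N3C2)c2ccccc12` has been run more than once; in this assay compound 1 gives 0.25 h; 0.3 h (2 entries). Compounds 1 and 2 differ in more than one place, so the two values are set down side by side and nothing further is drawn from them.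

Compound 3 `CC[C@@H]1C[C@H](C)CC/C=C\[C@@H]2C[C@@]2(C(=O)NS(=O)(=O)C2(C)CC2)NC(=O)[C@@H]2C[C@@H](Oc3ncc(OC)c4ccccc34)CN2C(=O)[C@H]1NC(=O)OC(C)(C)C(F)(F)F` is to be measured in this assay. It differs from compound 2 by methyl in place of hydrogen on a saturated ring carbon. For the measured compounds named here, no pair of measured compounds differs in this one place alone, so no measured step bears on it directly. The step is expected to be a 1.0-fold lower number from compound 2 to compound 3 (0.02 log units; within the scatter), within the usual scatter. For compound 3 the estimate is 0.6 h, expected to fall between 0.3 h and 1.2 h.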

Compound 3, half-life: 0.383 h
Compound 3: the middle estimate sits 1.6-fold (0.19 log units) above what was measured, within the range that was stated.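

In this assay, among the compounds shown here, the change from cyclopropylsulfonyl to (1-methylcyclopropyl)sulfonyl gives the first single-place step: a 1.6-fold lower number from compound 2 to compound 3 (0.21 log units; within the scatter). On this evidence, this saturated ring carbon accepts methyl in place of hydrogen with no step beyond the usual scatter, so the read-out does not separate compound 2 from compound 3. Repeat entries show how closely the read-out agrees with itself for one compound: the several entries of compound 1 in this assay, 0.25 h; 0.3 h (2 entries)

On these data alone, it remains open whether an ethyl chain, a trifluoromethyl or an amine on the same ring carbon would give a step beyond the scatter. Compound 1 also carries 1-methylcyclopropyl, but on a different core, and no partner with plain cyclopropyl on that core is among the compounds shown, so it remains open whether this step holds there.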